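The source may report more compounds than this note shows. Statements on the series, on what has been measured and on what is new or still open speak of the compounds shown alone.

Measured in a functional assay on NCI-H661 cells (Homo sapiens) for antiproliferative activity, read by MTT assay, with a stated time of 72 h; on this read-out higher numbers stand for weaker inhibition and lower numbers for stronger inhibition:
- Compound 1 `Nc1ccccc1NC(=O)CCCCCCc1nc(-c2ccc(C(F)(F)F)cc2)no1`: 29800 nM
- Compound 2 `Cc1ccc(-c2noc(CCCCCCC(=O)C(F)(F)F)n2)cc1`: 18700 nM

Compound 2, at 18700 nM, stands level with compound 1, since the two values lie within the usual scatter of each other. With only these two numbers, neither compound can be ranked above the other.

Compound 3 `O=C(CCCCCCc1nc(-c2ccc(C(F)(F)F)cc2)no1)C(F)(F)F` differs from compound 2 in one place: trifluoromethyl in place of methyl on an aromatic carbon. This puts trifluoromethyl in place of methyl on an aromatic carbon, para to a large group. Going by the values given here, no measured pair isolates this change. Compound 1 also carries a trifluoromethyl group and gives 29800 nM, so in this assay no step beyond the scatter is expected, in either direction. The expected change is a 1.1-fold lower number from compound 2 to compound 3 (0.04 log units; within the scatter). The estimated value for compound 3 is 17000 nM, with an expected range from 7000 nM to 40000 nM.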

Compound 3, half-maximal inhibitory concentration: 6390 nM
The estimate for compound 3 lay 2.7-fold (0.42 log units) above the measured number, and the stated range ends above it.
By their numbers in this assay, from the lowest: compound 3; then compounds 2 and 1 (each within the scatter of the next).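

In this assay the aromatic carbon para to a large group proves sensitive: trifluoromethyl in place of methyl gives a 2.9-fold lower number from compound 2 to compound 3 (0.47 log units; beyond the scatter) in this series, a change that compound 1 and compound 2 alone could not reveal. The carbonyl carbon also matters, since trifluoromethyl in place of (2-aminophenyl)amino there, with the aromatic trifluoromethyl kept, gives a 4.7-fold lower number from compound 1 to compound 3 (0.67 log units; beyond the scatter) in the same assay. No measurement at hand accounts for either step.

The compounds shown leave open whether a chlorine atom or a methoxy group on that aromatic carbon would behave like trifluoromethyl or like methyl. They also leave open how a hydroxamic acid on the carbonyl carbon, or a shorter or longer chain, would alter the values.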